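This account rests on a few compounds, and the source may have more. Where it says the series, first, only, none or still open, it means among the compounds named here.

Values in a functional assay on HCT-116 cells (Homo sapiens) for antiproliferative activity, read by MTT assay, with a stated time of 48 h (on this read-out lower numbers stand for stronger inhibition and higher numbers for weaker inhibition), are as follows.

- Compound 1 (`CC(CCO)n1cnc2c(Cl)nc(F)nc21`): 19800 nM
- Compound 2 (`CCCC(CCO)n1cnc2c(Cl)nc(F)nc21`): 16500 nM
- Compound 3 (`CCCC(CCO)n1cnc2c(Cl)ncnc21`): > 50000 nM (a limit, not a number)

Compound 3 has no number of its own and stands at the limit of > 50000 nM in this assay, at which 1 of the 3 values shown sits, within this small series. Compound 4 (`CCCCCC(CCO)n1cnc2c(Cl)ncnc21`) differs from it by ethyl in place of hydrogen on a saturated chain carbon, four bonds along the chain from an aromatic nitrogen and so carries ethyl in place of hydrogen on a saturated chain carbon, four bonds along the chain from an aromatic nitrogen. The nearest measured parallel is ethyl in place of hydrogen on a saturated chain carbon, two bonds along the chain from an aromatic nitrogen, and there the data show a 1.2-fold lower number from compound 1 to compound 2 (0.08 log units; within the scatter) in that pair. The other measured step, an at least 3.0-fold higher number from compound 2 to compound 3 (0.48 log units; beyond the scatter), is hydrogen in place of fluoro on an aromatic carbon, and compound 4 keeps that hydrogen, so this step does not carry over. In this assay no step beyond the scatter is therefore expected, and compound 4 may again return only a limit. The estimated step is an at least 1.1-fold lower number from compound 3 to compound 4 (0.04 log units; that floor lies within the scatter) in size. For compound 4 the estimate is 45000 nM, with an expected range from 20000 nM to 80000 nM.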

Compound 4, half-maximal inhibitory concentration: > 50000 nM
Compound 4 ended at the assay's limit; the forecaster's own chance of this, stated with the estimate: 55%; at least 1.1-fold (0.04 log units) between middle value and limit.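

In this assay, going by these compounds alone, compound 3 and compound 4 both stand at a limit, not a number, so no step between them can be read: the limit of > 50000 nM in this assay, at which 2 of the 4 values shown sit.

The compounds shown leave open whether ethyl in place of hydrogen changes the read-out at all where the aromatic carbon carries hydrogen instead of fluoro.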